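This account rests on a few compounds, and the source may have more. Where it says the series, first, only, none or still open, it means among the compounds named here.

The account follows compound 1 `COc1ccc(C23CCC(=O)N2CCCO3)cc1` toward compound 4 `O=C1CCC2(c3ccccc3)OCCCN12` in a functional assay on the whole organism with Mus musculus as the target, in the maximal electroshock model; a higher number here means that more compound is needed for the effect, a lower number that less compound is needed. In this assay compound 1 gives 93.8 mg/kg, the lowest of the two numbers reported, with compound 2 `O=C(CCC(=O)c1ccc(Cl)c(Cl)c1)NCCCO` as its nearest neighbour. In this assay compound 2 gives 450 mg/kg, a gap beyond the usual scatter. Compound 3 `O=C(CCC(=O)c1ccc(F)cc1)NCCCO` is reported in this assay only as a limit, > 400 mg/kg, which is the limit of > 400 mg/kg in this assay, at which 1 of the 3 values shown sits, and not a number. Compound 4 differs from compound 1 in one place: hydrogen in place of methoxy on an aromatic carbon. Going by the values given here, no measured pair among the three compounds shows this change, so its step in this assay has no direct precedent here. The step is expected to be small, within the scatter or at most modestly toward a higher number. For compound 4 the estimated result in this assay is 120 mg/kg, with a range from 45 mg/kg to 320 mg/kg. For compound 4 this estimate means an expected step of a 1.3-fold higher number from compound 1 to compound 4 (0.11 log units; within the scatter).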

Compound 4, dose for half-maximal effect: 92 mg/kg
Compound 4: the middle estimate sits 1.3-fold (0.12 log units) above what was measured; the range from low to high includes it.
By their numbers in this assay, from the lowest: compounds 4 and 1 (each within the scatter of the next); then compound 2.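

In this assay, going by these compounds alone, putting hydrogen in place of methoxy on the aromatic carbon para to a large group gives a 1.0-fold lower number from compound 1 to compound 4 (0.01 log units; within the scatter) and so provides the first measured pair for this change. The methoxy group, with its 2 heavy atoms and 1 hydrogen-bond acceptor, is therefore not required at this place for compound 4 to keep a number within the scatter of that of compound 1. Nothing in the data at hand bears on why this exchange leaves the result within the scatter.

Whether this position accepts other groups stays open, as the compounds shown include no amine, carboxylic acid or longer chain on this aromatic carbon. A single pair also cannot say whether the same exchange would read alike on a different core.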